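A Carbonyl Substituent Swap Awaiting Measurement

The compounds below may be only part of what the source reports. "The series", "measured", "known", "first", "only" and "open" are said of these compounds alone.

- Compound 1 `CC(=O)N1CCC(C(=O)N2CCC(N3CCN(C(=O)c4cc(-c5ccc(C)cc5)nc(-c5ccc(C)cc5)c4)CC3)CC2)CC1`: 343 nM
- Compound 2 `CC(=O)N1CCC(C(=O)N2CCC(N3CCN(C(=O)c4cc(-c5ccc(C)cc5)nc(-c5ccc6[nH]c(C)c(C)c6c5)c4)CC3)CC2)CC1`: 294 nM
- Compound 3 `CCNC(=O)Nc1sc2ccccc2c1C(=O)N1CCN(C2CCN(C(=O)C(C)(C)C)CC2)CC1`: 450 nM

All three values come from a functional assay on HepG2 cells (Homo sapiens) for inhibition, read by scintillation counting, with a stated time of 2 h; a lower number here means a stronger inhibitor, a higher number a weaker inhibitor. There, compound 3 gives 450 nM, which lies within the scatter of the values of both compound 1 and compound 2. On these numbers, the three compounds cannot be ranked.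

The next compound, compound 4 `CCNC(=O)Nc1sc2ccccc2c1C(=O)N1CCN(C2CCN(C(=O)OC(C)(C)CF)CC2)CC1`, has not yet been measured. It keeps the core of compound 3 and alters one group: a group of 6 heavy atoms (4 carbon, 1 oxygen, 1 fluorine; no ring) in place of a group of 4 heavy atoms (4 carbon; no ring), on a carbonyl carbon. The change lies on a carbonyl carbon whose other neighbours are an amide-type nitrogen in a ring.

For the measured compounds named here, only one measured step is available, a 1.2-fold lower number from compound 1 to compound 2 (0.07 log units; within the scatter). It lies within the scatter, but it concerns a group on an aromatic carbon, so it bears on the present change only loosely. Going by the values given here, no measured step touches the group on this carbonyl carbon, and the data therefore give no direction for the change. The expectation starts from compound 3 at 450 nM, and the step expected is a 1.3-fold lower number from compound 3 to compound 4 (0.11 log units; within the scatter), none beyond the scatter. For compound 4 the estimated value is 350 nM, with an expected range of 110 nM to 1100 nM.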

Compound 4, half-maximal inhibitory concentration: 61 nM
Compound 4: middle estimate off by 5.7-fold (0.76 log units), on the high side, outside the stated range (below it).
By their numbers in this assay, from the lowest: compound 4; then compounds 2, 1 and 3 (each within the scatter of the next).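

In this assay, replacing the tert-butyl group on the carbonyl carbon of compound 3 with the group of 6 heavy atoms gives a 7.4-fold lower number from compound 3 to compound 4 (0.87 log units; beyond the scatter). This is the first step here that lies beyond the scatter, whereas the only earlier step, a 1.2-fold lower number from compound 1 to compound 2 (0.07 log units; within the scatter), concerned a group on an aromatic carbon and stayed within it, so the number is now shown to respond to a change on this carbonyl carbon, whose other neighbours are an amide-type nitrogen in a ring. No measurement at hand accounts for the size of this step.

The change brings in an oxygen and a fluorine together, so the compounds shown do not tell which of the two goes with the lower number, and a tert-butoxy group on the same carbonyl carbon, carrying the oxygen without the fluorine, would separate them. They also leave open whether the step would hold on the core of compound 1, and how a longer carbon chain or an amine on this carbonyl carbon would read in this assay.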